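A Methoxy-for-Methyl Swap on the Benzyl Amide

The source may hold more compounds than are shown below. What is called first, only, known or untested is meant among the compounds shown, and "the series" means these compounds.

Compound 1 `Cc1ccc(CNC(=O)c2nc(-c3ccc(F)cc3)n(CC[C@@H](O)C[C@@H](O)CC(=O)O)c2C2CC2)cc1` stands lowest of the three numbers shown: in an assay on microsomes from liver for inhibition of 3-hydroxy-3-methylglutaryl-coenzyme A reductase (Rattus norvegicus), read by scintillation counting, with stated times of 0.5 h and 0.75 h (a higher number here means a weaker inhibitor, a lower number a stronger inhibitor), compound 1 gives 1.7 nM. Compound 2 `Cc1c(C(=O)NCc2ccccc2)nc(-c2ccc(F)cc2)n1CC[C@@H](O)C[C@@H](O)CC(=O)O` gives 94 nM in this assay, and compound 3 `CCc1c(C(=O)NCc2ccccc2)nc(-c2ccc(F)cc2)n1CC[C@@H](O)C[C@@H](O)CC(=O)O` gives 123 nM; both numbers lie well above that of compound 1. Going by the values given here, the only single-site step measured, a 1.3-fold higher number from compound 2 to compound 3 (0.12 log units; within the scatter), lies within the scatter and concerns a place other than the one altered here.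

Compound 4 `COc1cccc(CNC(=O)c2nc(-c3ccc(F)cc3)n(CC[C@@H](O)C[C@@H](O)CC(=O)O)c2C2CC2)c1` differs from compound 1 by 3-methoxyphenyl in place of 4-methylphenyl on a saturated chain carbon bound to an amide-type nitrogen. Among the compounds with values here, no measured step touches this benzyl ring, so the data give no direct guide to how the number responds to substituents there; the one step that is known, from compound 2 to compound 3, moved the number hardly at all. Compound 4 is therefore expected to change little, the expected step being a 1.8-fold higher number from compound 1 to compound 4 (0.25 log units; within the scatter) in this assay. The estimate for compound 4 is 3 nM, within a range of 1 nM to 10 nM.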

Compound 4, half-maximal inhibitory concentration: 1.2 nM
Compound 4: the middle estimate sits 2.5-fold (0.40 log units) above what was measured; the measured number falls inside the stated range.
By their numbers in this assay, from the lowest: compounds 4 and 1 (each within the scatter of the next); then compounds 2 and 3 (each within the scatter of the next).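

Going by these compounds alone, the first direct reading at this benzyl ring is a 1.4-fold lower number from compound 1 to compound 4 (0.15 log units; within the scatter) in this assay, so the change leaves compound 4 and compound 1 indistinguishable by this measure. This holds even though 3-methoxyphenyl carries an oxygen and a hydrogen-bond acceptor that 4-methylphenyl does not, so on the core of compound 1 this place accepts both groups with no difference beyond the scatter. No measurement is available that would account for this result.

The compounds shown leave open whether the methoxy group and its ring position each matter on their own: 4-methoxyphenyl or 3-methylphenyl in the same place would separate the two. Also open, on these data alone, is whether a more distinct group on this ring, such as an amine or a carboxylic acid, would leave the number as little moved.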